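A few compounds are considered here, and "the series" means these few. Any claim that something is new, unique, unknown or untested is made for them only; others in the source may bear on it.

Measured so far in a functional assay on HEK293 cells for agonist activity at Neuronal acetylcholine receptor; alpha4/beta2 (Homo sapiens), read by FLIPR; a lower number here means that less compound is needed, a higher number that more compound is needed for the effect:
compound 1 `COc1cncc(N2CC[C@@H]3CN[C@@H]3C2)c1`: 2700 nM
compound 2 `CCOc1cncc(N2CC[C@@H]3CN[C@@H]3C2)c1`: 1350 nM

Within the data shown here, compound 2 and compound 1 lie within the scatter of each other; the only measured step is a 2.0-fold lower number from compound 1 to compound 2 (0.30 log units; within the scatter), so the two numbers do not separate, and compound 2 cannot be called the more potent of the pair.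

Compound 3 `N/C(=N/O)c1cncc(N2CC[C@@H]3CN[C@@H]3C2)c1` has not been measured. It differs from compound 2 by a group of 4 heavy atoms (1 carbon, 2 nitrogen, 1 oxygen; no ring) in place of a group of 3 heavy atoms (2 carbon, 1 oxygen; no ring), on an aromatic carbon. Among the measured compounds shown here, the only step measured, a 2.0-fold lower number from compound 1 to compound 2 (0.30 log units; within the scatter), concerns a chain carbon of the ethoxy group and says nothing about exchanging the whole ethoxy for a group with two hydrogen-bond donors; there is no measured step of this kind to lean on. The expectation for compound 3 is therefore wide, centred on a step of a 1.5-fold higher number from compound 2 to compound 3 (0.17 log units; within the scatter) that is not expected to exceed the scatter in either direction. Compound 3 is estimated at 2000 nM, with a range from 300 nM to 15000 nM.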

Compound 3, half-maximal effective concentration: 180 nM
For compound 3 the middle estimate is 11-fold (1.05 log units) above the measured one; measured number outside the range, below it.
By their numbers in this assay, from the lowest: compound 3; then compounds 2 and 1 (each within the scatter of the next).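

In this assay, the aromatic carbon two atoms from the ring nitrogen proves responsive to the nature of its substituent: exchanging ethoxy for the group of 4 heavy atoms (1 carbon, 2 nitrogen, 1 oxygen; no ring) gives a 7.5-fold lower number from compound 2 to compound 3 (0.88 log units; beyond the scatter), and the same exchange starting from the group on this carbon in compound 1 gives a 15-fold lower number from compound 1 to compound 3 (1.18 log units; beyond the scatter). Among these compounds, the earlier change at this place, a 2.0-fold lower number from compound 1 to compound 2 (0.30 log units; within the scatter), did not separate its two compounds, so these are the first steps to show that the substituent at this carbon can move the number beyond the scatter, with compound 3 now lowest of the three. No available evidence bears on what lies behind this gain, so the result stands as an observation only.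

Still open, on these data alone, is whether the whole new group is needed for the lower number, or whether a nitrile, a primary carboxamide or a carboxylic acid on the same aromatic carbon would match it. Also open, as far as these compounds go, is whether the gain carries over to an amine or a longer chain bearing the same atoms at this position.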